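Reshaping the amine side group of compound 3

The source may hold more compounds than are shown below. What is called first, only, known or untested is meant among the compounds shown, and "the series" means these compounds.

Measured so far in a functional assay on MGC-803 cells (Homo sapiens) for cytotoxicity, read by MTT assay, with a stated time of 48 h; a lower number here means a stronger inhibitor, a higher number a weaker inhibitor:
compound 1 `O=C(c1ccccc1Cl)N1N=C(c2cc3ccccc3oc2=O)CC1c1ccccc1` gives 6640 nM here
compound 2 `CCCNCC(=O)N1N=C(c2cc3ccccc3oc2=O)CC1c1ccccc1` gives 4880 nM here
compound 3 `O=C(CNC1CCCCC1)N1N=C(c2cc3ccccc3oc2=O)CC1c1ccccc1` gives 26400 nM here

Compound 3 stands highest of the three, at 26400 nM in this assay. The change to compound 4 `CC1CCCCN1CC(=O)N1N=C(c2cc3ccccc3oc2=O)CC1c1ccccc1` is 2-methylpiperidin-1-yl in place of cyclohexylamino on a saturated chain carbon bound to a carbonyl carbon, with 2-methylpiperidin-1-yl in place of cyclohexylamino on a saturated chain carbon bound to a carbonyl carbon. Among the compounds with values here, no measured step makes this change itself. The closest is the swap of propyl for cyclohexyl on an amine nitrogen, a 5.4-fold higher number from compound 2 to compound 3 (0.73 log units; beyond the scatter), and a 4.0-fold higher number from compound 1 to compound 3 (0.60 log units; beyond the scatter) is of similar size, while a 1.4-fold lower number from compound 1 to compound 2 (0.13 log units; within the scatter) shows no separation. Only compound 3 carries cyclohexylamino, so a modest move towards a lower number is expected, estimated as a 2.2-fold lower number from compound 3 to compound 4 (0.34 log units; beyond the scatter) in this assay. Compound 4 is estimated at 12000 nM with 4500 nM to 32000 nM as the expected range.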

Compound 4, half-maximal inhibitory concentration: "not active" (no number reported)
The entry for compound 4 holds no number; no gap can be computed for the estimate.
By their numbers in this assay, from the lowest: compounds 2 and 1 (each within the scatter of the next); then compound 3.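

In this assay, within the data shown here, compound 4 is reported only as "not active", with no number, and no step from compound 3 to compound 4 can be read. On these data alone, how far 2-methylpiperidin-1-yl moves the number from where cyclohexylamino puts it stays open. Nothing available explains this result.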